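Chalcone series: fluorophenyl to fluoropyridinyl exchange on two cores

A few compounds are considered here, and "the series" means these few. Any claim that something is new, unique, unknown or untested is made for them only; others in the source may bear on it.

Compound 1 `COc1ccc(/C=C/C(=O)c2ccccc2-c2ccc(F)cc2)cc1OC` and compound 2 `COc1ccc(/C=C/C(=O)c2ccccc2-c2ccc(F)nc2)cc1OC` share one core; the change from compound 1 to compound 2 is 6-fluoropyridin-3-yl in place of 4-fluorophenyl on an aromatic carbon. In a functional assay on HepG2 cells (Homo sapiens) for antiproliferative activity, read by sulforhodamine B assay, with a stated time of 48 h (on this read-out lower numbers stand for stronger inhibition and higher numbers for weaker inhibition), compound 1 gives 95 nM, and compound 2 gives 1000 nM; the step is an 11-fold higher number from compound 1 to compound 2 (1.02 log units; beyond the scatter). Compound 3 `COc1cc(C(=O)/C=C/c2ccccc2-c2ccc(F)cc2)ccc1O` carries a different core, and the difference between the cores of compound 1 and compound 3 is not broken down here. In this assay compound 3 gives 3100 nM, the highest of the three numbers. Compound 4 `COc1cc(C(=O)/C=C/c2ccccc2-c2ccc(F)nc2)ccc1O` has not yet been measured; from compound 3 it differs by 6-fluoropyridin-3-yl in place of 4-fluorophenyl on an aromatic carbon, the same change at the same place as between compound 1 and compound 2. This change has been made only once so far, so its transfer to the core of compound 3 rests on a single example. In this assay the expected step is an 8.1-fold higher number from compound 3 to compound 4 (0.91 log units; beyond the scatter), kept close to the earlier one, because the earlier one was an 11-fold higher number from compound 1 to compound 2 (1.02 log units; beyond the scatter). Compound 4 is therefore estimated at 25000 nM, with a range from 8000 nM to 80000 nM.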

Compound 4, half-maximal inhibitory concentration: 9900 nM
The estimate for compound 4 lay 2.5-fold (0.40 log units) above the measured number; the range from low to high includes it.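

In this assay, 6-fluoropyridin-3-yl in place of 4-fluorophenyl again gives weaker inhibition on the second core, with a 3.2-fold higher number from compound 3 to compound 4 (0.50 log units; beyond the scatter). The direction of the change carries over between these two cores, but its size does not: the same change on two cores in this assay, an 11-fold higher number (1.02 log units; beyond the scatter) from compound 1 to compound 2 and a 3.2-fold higher number (0.50 log units; beyond the scatter) from compound 3 to compound 4, 3.3-fold (0.52 log units) apart, beyond the scatter of two such steps. This shows that the size of the step depends on the core in these two examples, but it does not show which part of the core is responsible, and the difference between the cores of compound 1 and compound 3 is not broken down here.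

From the compounds shown here alone, it remains open whether the exchange would keep its direction on further cores, and whether the step there would lie nearer the larger or the smaller of these two. Also open, going by these compounds, is how other groups on this aromatic carbon would read in this assay, for example an unsubstituted phenyl, a pyridinyl without fluorine or a phenyl carrying an amine.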